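From methylamino to ethylamino in a flat cytotoxicity series

The source may hold more compounds than are shown below. What is called first, only, known or untested is meant among the compounds shown, and "the series" means these compounds.

Measured in a functional assay on G-361 cells (Homo sapiens) for cytotoxicity, read by MTT assay, with a stated time of 3 days; a higher number here means a weaker inhibitor, a lower number a stronger inhibitor:
- compound 1 `N#Cc1c(Cl)nc(SCc2nc3ccccc3[nH]2)nc1-c1ccccc1`: 12.5 nM
- compound 2 `N#Cc1c(NN)nc(SCc2nc3ccccc3[nH]2)nc1-c1ccccc1`: 14.7 nM
- compound 3 `CNc1nc(SCc2nc3ccccc3[nH]2)nc(-c2ccccc2)c1C#N`: 12.5 nM

Compound 3, at 12.5 nM, stands level with compound 1, and compound 2 lies within the scatter of both. The next structure, compound 4 `CCNc1nc(SCc2nc3ccccc3[nH]2)nc(-c2ccccc2)c1C#N`, puts methyl in place of hydrogen on a saturated chain carbon bound to a nitrogen on an aromatic ring, so that methylamino becomes ethylamino (methyl in place of hydrogen on a saturated chain carbon bound to a nitrogen on an aromatic ring). Among the compounds with values here, no measured step makes this exact change, so the evidence is indirect. The closest is the change at the same nitrogen, a 1.2-fold lower number from compound 2 to compound 3 (0.07 log units; within the scatter). The replacements of chloro gave a 1.2-fold higher number from compound 1 to compound 2 (0.07 log units; within the scatter) and no change at the digits printed from compound 1 to compound 3 (within the scatter). All three steps stay within the scatter, so no step beyond the scatter is expected in this assay, and no direction is favoured. The estimated step is a 1.0-fold higher number from compound 3 to compound 4 (0.02 log units; within the scatter). Compound 4 is expected at about 13 nM, with an estimated range of 7.5 nM to 23 nM.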

Compound 4, half-maximal inhibitory concentration: 4.38 nM
Beside the measured number, compound 4's estimate is 3.0-fold (0.47 log units) above it; the whole stated range lies above it.
By their numbers in this assay, from the lowest: compound 4; then compounds 1, 3 and 2 (each within the scatter of the next).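

In this assay, within the data shown here, ethylamino is the first group at this position to move the number beyond the scatter, with a 2.9-fold lower number from compound 3 to compound 4 (0.46 log units; beyond the scatter) for the addition of a single methyl on a saturated chain carbon bound to a nitrogen on an aromatic ring. The gain also holds against the other two groups, with a 3.4-fold lower number from compound 2 to compound 4 (0.53 log units; beyond the scatter) and a 2.9-fold lower number from compound 1 to compound 4 (0.46 log units; beyond the scatter), whereas chloro, aminoamino and methylamino had stayed within the scatter of one another, so this position is not indifferent to the group it carries. No measurement at hand explains this step.

One ethyl group cannot show whether the number keeps falling as the chain grows. A longer chain such as propylamino, a branched isopropylamino or a ring amine such as morpholine could continue the fall, level off or reverse it.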